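The compounds below may be only part of what the source reports. "The series", "measured", "known", "first", "only" and "open" are said of these compounds alone.

Three compounds share a core. Compound 1 `c1ccc(-c2ccnc(Nc3cccc(OCCn4ccnc4)c3)n2)nc1` bears a 2-(1H-imidazol-1-yl)ethoxy group on an aromatic carbon, and in a functional assay for inhibition, with Homo sapiens as the target (a higher number here means a weaker inhibitor, a lower number a stronger inhibitor), compound 1 gives 400 nM. Compound 2 `CC(=O)Nc1cccc(Nc2nccc(-c3ccccn3)n2)c1` carries an acetamido group in its place; in this assay compound 2 gives 300 nM, and the step of a 1.3-fold lower number from compound 1 to compound 2 (0.12 log units; within the scatter) lies within the scatter. Compound 3 `COc1cccc(Nc2nccc(-c3cccnc3)n2)c1` has a methoxy group on an aromatic carbon and a pyridin-3-yl group on the core; in this assay compound 3 gives 300 nM, level with compound 2 at the digits shown and within the scatter of compound 1, so the three compounds stand together.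

Compound 4 `COc1cccc(Nc2nccc(-c3ccccn3)n2)c1` keeps the methoxy group and differs from compound 3 only in how the same atoms are joined: pyridin-2-yl in place of pyridin-3-yl on an aromatic carbon. Within the data shown here, no measured step exchanges pyridin-3-yl for pyridin-2-yl, so nothing bears on the change directly. Compound 1 already carries pyridin-2-yl with another group and gives 400 nM, and compound 2 likewise carries pyridin-2-yl and gives 300 nM, both close to compound 3. Compound 4 is therefore expected to show no step beyond the scatter, no change at the digits printed from compound 3 to compound 4 (within the scatter). The estimate for compound 4 in this assay is 300 nM, within 120 nM to 800 nM.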

Compound 4, half-maximal inhibitory concentration: 200 nM
For compound 4 the middle estimate is 1.5-fold (0.18 log units) above the measured one, within the range that was stated.
By their numbers in this assay, from the lowest: compounds 4, 2, 3 and 1 (each within the scatter of the next).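

Among these compounds, exchanging pyridin-3-yl for pyridin-2-yl on the aromatic carbon next to the ring nitrogen of the shared core gives a 1.5-fold lower number from compound 3 to compound 4 (0.18 log units; within the scatter) in this assay and is the first direct reading of this change: the two arrangements of the same atoms cannot be told apart here. With pyridin-2-yl held in place, the group at the other end of the molecule can now also be compared: methoxy in place of acetamido gives a 1.5-fold lower number from compound 2 to compound 4 (0.18 log units; within the scatter) and hydrogen in place of (1H-imidazol-1-yl)methyl on the saturated chain carbon bound to an oxygen on an aromatic ring gives a 2.0-fold lower number from compound 1 to compound 4 (0.30 log units; within the scatter) so that all three steps stay within the scatter, and this set shows no dependence on either site. No measurement in hand accounts for this flat picture.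

Still open, as far as these compounds go, is whether pyridin-4-yl or a plain phenyl ring on the same aromatic carbon would stay level with these compounds. Also open, from the compounds shown here alone, is whether an amine or a carboxylic acid at the end of a longer chain in place of the methoxy group would move the number beyond the scatter.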